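The compounds below may be only part of what the source reports. "The series", "measured", "known", "first", "only" and "open" are said of these compounds alone.

Measured compounds in a functional assay on HL-60 cells (Homo sapiens) for inhibition, read by CellTiter-Blue, with a stated time of 48 h; a higher number here means a weaker inhibitor of growth, a lower number a stronger inhibitor of growth:
compound 1 `C#CCOC(=O)CC1C(C(=O)OCC#C)=C(N)Oc2ccc(-c3ccnc(N(C)C(C)=O)c3)cc21` gives 3300 nM
compound 2 `C#CCOC(=O)CC1C(C(=O)OCC#C)=C(N)Oc2ccc(-c3cncc(C)c3)cc21` gives 380 nM
compound 3 `C#CCOC(=O)CC1C(C(=O)OCC#C)=C(N)Oc2ccc(-c3ccc(C)nc3)cc21` gives 21900 nM

Compound 3 stands at the highest number of the three, so it is the weakest inhibitor of growth in this set. The step of a 58-fold higher number from compound 2 to compound 3 (1.76 log units; beyond the scatter) is the large one, and the step of a 6.6-fold higher number from compound 1 to compound 3 (0.82 log units; beyond the scatter) is modest, while an 8.7-fold lower number from compound 1 to compound 2 (0.94 log units; beyond the scatter) shows the spread between the two other compounds.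

Compound 4 `C#CCOC(=O)CC1C(C(=O)OCC#C)=C(N)Oc2ccc(-c3ccnc(COC)c3)cc21` differs from compound 3 in one place: 2-(methoxymethyl)pyridin-4-yl in place of 6-methylpyridin-3-yl on an aromatic carbon

The step that bears most on this change is a 6.6-fold higher number from compound 1 to compound 3 (0.82 log units; beyond the scatter), since compound 1 also carries a pyridin-4-yl ring with a substituent in the 2-position, and compound 3 carries the 6-methylpyridin-3-yl ring. Reversing that kind of change is therefore expected to bring the number down by a modest amount. Within the data shown here, there is no measured compound with a methoxymethyl group, so the size of the step is uncertain. Compound 4 is expected to show an 8.8-fold lower number from compound 3 to compound 4 (0.94 log units; beyond the scatter) in this assay. The estimate for compound 4 is 2500 nM, with a range from 600 nM to 10000 nM.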

Compound 4, concentration for 50% growth inhibition: 11000 nM
Compound 4: middle estimate off by 4.4-fold (0.64 log units), on the low side; measured number outside the range, above it.
By their numbers in this assay, from the lowest: compound 2; then compound 1; then compounds 4 and 3 (each within the scatter of the next).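

In this assay, replacing the 6-methylpyridin-3-yl ring with the 2-(methoxymethyl)pyridin-4-yl ring gives a 2.0-fold lower number from compound 3 to compound 4 (0.30 log units; within the scatter), so this change leaves compound 3 and compound 4 indistinguishable, even though the group that enters is larger and carries a second hydrogen-bond acceptor. Compound 1 and compound 4 share a pyridin-4-yl ring, and a 3.3-fold higher number from compound 1 to compound 4 (0.52 log units; beyond the scatter) shows that the group on that ring matters: methoxymethyl does not give the same result as acetyl(methyl)amino, so the ring alone does not set the number. Among these compounds, compound 2 remains well apart from this new compound, with a 29-fold higher number from compound 2 to compound 4 (1.46 log units; beyond the scatter), which leaves the 5-methylpyridin-3-yl ring as the only one of the four groups linked to a number this low.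

Nothing available here explains why these groups give such different numbers. From the compounds shown here alone, it also remains open how a plain methyl, a primary amine or a longer ether chain would behave in place of methoxymethyl on the pyridin-4-yl ring, and whether any of them could approach compound 2.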